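The source may report more compounds than this note shows. Statements on the series, on what has been measured and on what is new or still open speak of the compounds shown alone.

Measured compounds in an assay on isolated protein for inhibition of proto-oncogene tyrosine-protein kinase receptor Ret variant V804M (Homo sapiens), read by 33P incorporation, with stated times of 15 min and 40 min; on this read-out higher numbers stand for weaker inhibition and lower numbers for stronger inhibition:
compound 1 `CC(C)(C)c1cc(NC(=O)Nc2ccc(Nc3ncnc4c3OCCN4)cc2)no1`: 34 nM
compound 2 `Cc1cc(NC(=O)Nc2cc(C(C)(C)C)on2)ccc1Nc1ncnc2c1OCCN2`: 44 nM
compound 3 `Cc1nc(Nc2ncnc3c2OCCN3)ccc1NC(=O)Nc1cc(C(C)(C)C)on1`: 1110 nM

Compound 2 stands second highest of these three numbers. Compound 1 lies within the scatter of it, and compound 3, at 1110 nM, lies far above compound 2 at 44 nM. The next step leads to compound 4 `CC(C)(C)c1cc(NC(=O)Nc2ccc(Nc3ncnc4c3OCCN4)c(O)c2)no1` by hydroxy in place of methyl on an aromatic carbon. Among the compounds with values here, only one measured step bears on that carbon: a 1.3-fold higher number from compound 1 to compound 2 (0.11 log units; within the scatter), which shows that putting a methyl there changed nothing beyond the scatter. Within the data shown here, no measured step shows a hydroxy entering anywhere, so the expectation rests on that single small step alone. A step within or near the scatter is therefore expected in this assay, in no firm direction, a 1.1-fold higher number from compound 2 to compound 4 (0.06 log units; within the scatter). Compound 4 is expected to give about 50 nM, between 15 nM and 170 nM.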

Compound 4, half-maximal inhibitory concentration: 63 nM
Estimate against measurement, compound 4: 1.3-fold (0.10 log units) below; low and high end bracket the measured number.
By their numbers in this assay, from the lowest: compounds 1, 2 and 4 (each within the scatter of the next); then compound 3.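

In this assay, hydroxy in place of methyl gives a 1.4-fold higher number from compound 2 to compound 4 (0.16 log units; within the scatter), and hydroxy in place of hydrogen gives a 1.9-fold higher number from compound 1 to compound 4 (0.27 log units; within the scatter). Hydrogen, methyl and hydroxy on this aromatic carbon thus all lie within the scatter of one another, even though hydroxy brings a hydrogen-bond donor and acceptor that methyl lacks. No evidence here accounts for this. As far as these compounds go, whether an amine, a methoxy or a longer chain on the same carbon would also stay within the scatter remains open.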